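Working notes: from nitro to methoxy on the phenyl group

The source may hold more compounds than are shown below. What is called first, only, known or untested is meant among the compounds shown, and "the series" means these compounds.

Measured so far in a physicochemical assay for solubility, in phosphate buffer, at pH 7.4 (a lower number here means a less soluble compound, a higher number a more soluble compound), follow
- compound 1 `CCOC(=O)c1c(-c2ccccc2Cl)[nH]c2cc(OC)ccc2c1=O` gives 28000 nM
- compound 2 `CCOC(=O)c1c(-c2cccc([N+](=O)[O-])c2)[nH]c2cc(OC)ccc2c1=O` gives 13000 nM

Compound 2 holds the lower of the two numbers, at 13000 nM in this assay as the starting point. Compound 3 `CCOC(=O)c1c(-c2cccc(OC)c2)[nH]c2cc(OC)ccc2c1=O` has methoxy in place of nitro on an aromatic carbon and is still unmeasured. Going by the values given here, the only measured guide is modest, a 2.2-fold lower number from compound 1 to compound 2 (0.33 log units; beyond the scatter) with 3-nitrophenyl in place of 2-chlorophenyl. From that single step, no change beyond the scatter is expected in this assay and no direction can be assigned. The expected step is a 1.3-fold higher number from compound 2 to compound 3 (0.12 log units; within the scatter) on this estimate. Compound 3 is expected at 17000 nM with an estimated range of 8000 nM to 36000 nM in this assay here.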

Compound 3, solubility: > 100000 nM
Compound 3: no number, only a limit; the forecaster's own chance of this, stated with the estimate: 3%; middle value at least 5.8-fold (0.76 log units) away from the limit.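

In this assay compound 3 gives > 100000 nM, which is a limit of the assay and not a number. The group on this aromatic carbon can move the read-out well beyond the scatter: methoxy in place of nitro gives an at least 7.6-fold higher number from compound 2 to compound 3 (0.88 log units; beyond the scatter), and 3-methoxyphenyl in place of 2-chlorophenyl gives an at least 3.5-fold higher number from compound 1 to compound 3 (0.55 log units; beyond the scatter). Both steps rest on a single limit: the limit of > 100000 nM in this assay, at which 1 of the 3 values shown sits.

As far as these compounds go, how far compound 3 lies past that limit stays open. Also open, from the compounds shown here alone, is what an amine, a carboxylic acid or a longer alkoxy chain would give at this place.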